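Compound 3 to compound 4: expected cytotoxicity shift

The source may hold more compounds than are shown below. What is called first, only, known or untested is meant among the compounds shown, and "the series" means these compounds.

Measured compounds:
compound 1 `O=C(NC(=S)N1CCc2c(OCCCCCOc3ccc(Cl)cc3)cccc21)Oc1ccccc1`, > 50000 nM (a limit of the assay, not a number)
compound 2 `N#Cc1cccc(C(=O)NC(=S)N2CCc3c(OCCCCCOc4ccc(Cl)cc4)cccc32)c1`, 9750 nM
compound 3 `COc1ccc(C(=O)NC(=S)N2CCc3c(OCCCCCOc4ccc(Cl)cc4)cccc32)cc1`, 34400 nM

In an ADME assay on Huh-7 cells (Homo sapiens) for cytotoxicity (on this read-out lower numbers stand for higher toxicity in this test and higher numbers for lower toxicity in this test), compound 1 sits at the limit (the limit of > 50000 nM in this assay, at which 1 of the 3 values shown sits). Among the two numbers, compound 3 gives the higher one, a 3.5-fold higher number from compound 2 to compound 3 (0.55 log units; beyond the scatter); the step of an at least 1.4-fold lower number from compound 1 to compound 3 (0.16 log units; that floor lies within the scatter) has a floor within the scatter. Compound 4 `O=C(NC(=S)N1CCc2c(OCCCCCOc3ccc(Cl)cc3)cccc21)c1ccc2ccccc2c1` carries the change (naphthalen-2-yl in place of 4-methoxyphenyl on a carbonyl carbon). Going by the values given here, no measured step exchanges one carbon-only aryl for another; the nearest reference is a 3.5-fold higher number from compound 2 to compound 3 (0.55 log units; beyond the scatter), a modest move from a ring-substituent change. A modest shift toward a lower number is therefore expected, a 1.9-fold lower number from compound 3 to compound 4 (0.28 log units; within the scatter), with direction uncertain. Compound 4 is estimated at 18000 nM, within 6000 nM to 50000 nM.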

Compound 4, half-maximal cytotoxic concentration: > 50000 nM
Compound 4: only a limit was reported; the forecaster's own chance of this, stated with the estimate: 15%; middle value at least 2.7-fold (0.44 log units) away from the limit.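

In this assay, a second carbon-only aromatic ring at this position does not bring the number down: naphthalen-2-yl on the carbonyl carbon gives an at least 5.1-fold higher number from compound 2 to compound 4 (0.70 log units; beyond the scatter). Against 4-methoxyphenyl the step is an at least 1.4-fold higher number from compound 3 to compound 4 (0.16 log units; that floor lies within the scatter), so that change cannot be told from scatter. The step between compound 1 and compound 4 cannot be read, as both values are limits: the limit of > 50000 nM in this assay, at which 2 of the 4 values shown sit.

Open, on these data alone, is how far compound 4 lies past its limit. Also open, as far as these compounds go, is whether an amine or a carboxylic acid on the aryl ring would lower the number, as 3-cyanophenyl does in compound 2.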